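Moving from a bromo to two methyls on the aryl ether

A few compounds are considered here, and "the series" means these few. Any claim that something is new, unique, unknown or untested is made for them only; others in the source may bear on it.

Measured so far:
compound 1 `NC1=NC2(CCOCC2)N(OCCCOc2ccc(Cl)cc2)C(N)=N1` with 690 nM
compound 2 `NC1=NC2(CCOCC2)N(OCCCOc2ccc(Br)cc2)C(N)=N1` with 320 nM

Both were tested in a functional assay on HCT-116 cells (Homo sapiens) for antiproliferative activity, read by MTT assay, with a stated time of 72 h; on this read-out higher numbers stand for weaker inhibition and lower numbers for stronger inhibition. Compound 2 gives the lowest of the two numbers, with compound 1 nearest at a 2.2-fold lower number from compound 1 to compound 2 (0.33 log units; beyond the scatter). Compound 3 `Cc1cc(C)cc(OCCCON2C(N)=NC(N)=NC23CCOCC3)c1` has not been measured; it differs from compound 2 by 3,5-dimethylphenyl in place of 4-bromophenyl on an oxygen on a saturated carbon. For the measured compounds named here, the only measured step exchanges one halogen for another, so it tells nothing direct about this change. A modest shift in either direction is expected, a 1.9-fold higher number from compound 2 to compound 3 (0.27 log units; within the scatter). Compound 3 is estimated at 600 nM, with a range of 200 nM to 2000 nM.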

Compound 3, half-maximal inhibitory concentration: 190 nM
The estimate for compound 3 lay 3.2-fold (0.50 log units) above the measured number; measured number below the stated range.
By their numbers in this assay, from the lowest: compounds 3 and 2 (each within the scatter of the next); then compound 1.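

In this assay the change to two methyls gives a 1.7-fold lower number from compound 2 to compound 3 (0.23 log units; within the scatter) and so leaves compound 2 and compound 3 indistinguishable, while the change from the chloro ring gives a 3.6-fold lower number from compound 1 to compound 3 (0.56 log units; beyond the scatter) and that gap is real. A halogen on the aryl ring is therefore not required at this level of activity, since 3,5-dimethylphenyl serves as well as 4-bromophenyl. Going by these compounds, it remains open whether a single methyl, a methoxy or an amine on this ring would do the same. Nothing available explains this result.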